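This account rests on a few compounds, and the source may have more. Where it says the series, first, only, none or still open, it means among the compounds named here.

Values in a functional assay on HeLa cells (Homo sapiens) for inhibition, read by MTT assay, with a stated time of 72 h (on this read-out higher numbers stand for weaker inhibition and lower numbers for stronger inhibition), follow.

Compound 1 `CC(C)C[C@H](NC(=O)CCC[C@H](NC(=O)OC(C)(C)C)C(=O)NCc1ccc2ccccc2c1)B(O)O` gives > 10000 nM as a limit
Compound 2 `CC(C)C[C@H](NC(=O)CC[C@H](NC(=O)CNC(=O)OC(C)(C)C)C(=O)NCc1ccccc1)B(O)O` gives 5110 nM as a number

Compound 1 stands at the limit of > 10000 nM in this assay, at which 1 of the 2 values shown sits, and so carries a limit and no number. Compound 3 `CC(C)C[C@H](NC(=O)CCC[C@H](NC(=O)[C@H](C)NC(=O)OC(C)(C)C)C(=O)NCc1ccc2ccccc2c1)B(O)O` has 1-((tert-butoxycarbonyl)amino)ethyl in place of tert-butoxy on a carbonyl carbon and otherwise matches compound 1. A moderate gain in inhibition is expected, estimated as an at least 2.5-fold lower number from compound 1 to compound 3 (0.39 log units; beyond the scatter) and resting on this single change, though the reading may again stop at the limit. Compound 3 is expected at 4000 nM with 800 nM to 10000 nM as the estimated range in this assay for this compound.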

Compound 3, half-maximal inhibitory concentration: > 10000 nM
Compound 3: a limit, no number (the forecaster's own chance of this, stated with the estimate: 30%); middle value at least 2.5-fold (0.39 log units) from the limit.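

For the compounds shown here, compound 3 gives > 10000 nM, a limit and not a number, and with compound 1 also at a limit, no step between the two can be read. The compounds shown leave open whether 1-((tert-butoxycarbonyl)amino)ethyl in place of tert-butoxy shifts inhibition at all in this assay.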